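The source may hold more compounds than are shown below. What is called first, only, known or untested is meant among the compounds shown, and "the series" means these compounds.

Compound 1 `CN(c1ccc2cc(NC(=O)CCc3ccc(C(F)(F)F)cc3)ccc2n1)C1CCCCC1` gives 18 nM in an assay on isolated protein for displacement of a labelled ligand from melanin-concentrating hormone receptor 1 (Homo sapiens); a lower number here means a stronger inhibitor, a higher number a weaker inhibitor.
Compound 2 `NC1CCN(c2ccc3cc(NC(=O)CCc4ccc(C(F)(F)F)cc4)ccc3n2)C1` gives 12 nM in this assay.

Within the data shown here, compound 2 has the lower of the two numbers so far, but the only measured step, a 1.5-fold lower number from compound 1 to compound 2 (0.18 log units; within the scatter), lies within the scatter, so the two compounds cannot really be told apart. Compound 3 `O=C(CCc1ccc(C(F)(F)F)cc1)Nc1ccc2nc(N3CCCCC3)ccc2c1` has not yet been measured. It differs from compound 2 in one place: piperidin-1-yl in place of 3-aminopyrrolidin-1-yl on an aromatic carbon. Among the measured compounds shown here, the one step that bears on this is the step from the amine group of compound 1 to that of compound 2, a 1.5-fold lower number from compound 1 to compound 2 (0.18 log units; within the scatter), where a group without a hydrogen-bond donor and one with a donor at this position gave numbers within the scatter of each other. On that basis the change to compound 3 is expected to give no step beyond the scatter, a 2.1-fold higher number from compound 2 to compound 3 (0.32 log units; beyond the scatter). Compound 3 is therefore estimated at 25 nM, with a range from 8 nM to 80 nM.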

Compound 3, half-maximal inhibitory concentration: 12 nM
For compound 3 the middle estimate is 2.1-fold (0.32 log units) above the measured one; the range from low to high includes it.
By their numbers in this assay, from the lowest: compounds 2, 3 and 1 (each within the scatter of the next).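

In this assay, exchanging 3-aminopyrrolidin-1-yl for piperidin-1-yl gives no change at the digits printed from compound 2 to compound 3 (within the scatter) even though the entering group has no hydrogen-bond donor, one hetero atom fewer and a six-membered rather than a five-membered ring. Exchanging cyclohexyl(methyl)amino for piperidin-1-yl gives a 1.5-fold lower number from compound 1 to compound 3 (0.18 log units; within the scatter), so all three groups on this aromatic carbon next to the ring nitrogen now sit within the scatter of one another, and the amine of compound 2 shows no measurable gain here. Nothing available explains why these groups cannot be told apart.

As far as these compounds go, all three groups are attached through nitrogen, so it remains open what a phenyl ring attached directly through carbon would give. Also open, from the compounds shown here alone, is whether a carboxylic acid on the piperidine ring would stay within the scatter.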